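The source may report more compounds than this note shows. Statements on the series, on what has been measured and on what is new or still open speak of the compounds shown alone.

In a functional assay on MCF7 cells (Homo sapiens) for cytotoxicity, read by MTT assay (on this read-out lower numbers stand for stronger inhibition and higher numbers for weaker inhibition), compound 1 (`COc1cc2ncnc(Nc3cc(-c4ccccc4)[nH]n3)c2cc1OC`) shows < 100000 nM and this is a limit, not a number. Compound 2 (`COc1cc2ncnc(Nc3cc(-c4ccc(F)cc4)[nH]n3)c2cc1OC`) shows < 100000 nM and this too is only a limit. Among the measured compounds shown here, the two readings share one limit (the limit of < 100000 nM in this assay, at which 2 of the 2 values shown sit), so the only measured step (a step that the two limits leave unreadable from compound 1 to compound 2) offers no size to carry over. Compound 3 (`COc1cc2ncnc(Nc3cc(-c4ccc(Cl)cc4)[nH]n3)c2cc1OC`) carries chloro in place of fluoro on an aromatic carbon. With no readable step as a guide, no direction can be given, and no change beyond the scatter is expected. The estimated step (a step that the limit leaves unreadable from compound 2 to compound 3) reflects that expectation. Compound 3 is expected at 30000 nM (estimated range 6000 nM to 100000 nM).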

Compound 3, half-maximal inhibitory concentration: < 100000 nM
Compound 3: no number, only a limit (the forecaster's own chance of this, stated with the estimate: 60%); the middle value lies beyond the limit too.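

No step among compound 1, compound 2 and compound 3 can be read, since each reading is only a limit: the limit of < 100000 nM in this assay, at which 3 of the 3 values shown sit.

The compounds shown leave open how strongly each acts in this assay, and whether hydrogen, fluoro or chloro changes that at all.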